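The compounds below may be only part of what the source reports. "The series", "measured", "known", "first", "only" and "open" are said of these compounds alone.

Measured so far in an ADME assay on MDCK-II cells (Canis lupus familiaris) for permeability (on this read-out higher numbers stand for higher permeability and lower numbers for lower permeability), are three compounds:
compound 1 `Cc1cc(=O)[nH]c(-c2cc(Oc3ccc(S(C)(=O)=O)cc3)cc(OC(C)C)c2)n1` with 4.8 10^-6 cm/s
compound 2 `CC(C)Oc1cc(Oc2cnc(C(=O)N(C)C)nc2)cc(-c2nccc(=O)[nH]2)c1` with 7.1 10^-6 cm/s
compound 3 `CC(C)Oc1cc(Oc2ccc(S(C)(=O)=O)cc2)cc(-c2ncc(C(C)C)c(=O)[nH]2)c1` with "not determined" (no result reported)

Compound 2 (7.1 10^-6 cm/s) and compound 1 (4.8 10^-6 cm/s) lie within the usual scatter of each other, so neither stands apart, and compound 3 gave no number. The unmeasured compound 4 `CN(C)C(=O)c1ncc(Oc2cc(OC3CCCC3)cc(-c3nccc(=O)[nH]3)c2)cn1` has cyclopentyl in place of isopropyl on an oxygen on an aromatic ring. Among the measured compounds shown here, no measured pair shows a change of this kind, so in this assay no step beyond the scatter is expected, in either direction. The estimated step is small (a 1.1-fold higher number from compound 2 to compound 4 (0.05 log units; within the scatter)). For compound 4 the expected value is 8 10^-6 cm/s with an estimated range from 3.5 10^-6 cm/s to 16 10^-6 cm/s in this measurement.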

Compound 4, apparent permeability in the MDCK-II assay: 14 10^-6 cm/s
Compound 4: the middle estimate sits 1.8-fold (0.24 log units) below what was measured; low and high end bracket the measured number.
By their numbers in the MDCK-II assay, from the lowest: compounds 1, 2 and 4 (each within the scatter of the next, the first and the last beyond it).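

Among the compounds shown here, compound 2 and compound 4 give the first pair that changes this oxygen substituent, with cyclopentyl in place of isopropyl. In the MDCK-II assay compound 2 gives 7.1 10^-6 cm/s and compound 4 gives 14 10^-6 cm/s, which is a 2.0-fold higher number from compound 2 to compound 4 (0.29 log units; within the scatter). In a physicochemical assay for solubility, in phosphate buffer, measured as kinetic solubility, with a stated time of 24 h, at pH 6.5 (a higher number here means a more soluble compound, a lower number a less soluble compound), compound 2 gives 332000 nM and compound 4 gives 398000 nM, which is a 1.2-fold higher number from compound 2 to compound 4 (0.08 log units; within the scatter), so neither read-out separates the two compounds. Nothing available offers an explanation for these steps.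

On these data alone, what an amine or a longer chain on this oxygen would do in either read-out stays open. So does whether the same change would give similar steps on the core of compound 1.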